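Swapping a silyl ether for a dimethylamino tail

A few compounds are considered here, and "the series" means these few. Any claim that something is new, unique, unknown or untested is made for them only; others in the source may bear on it.

Measured compounds:
compound 1 `Cn1c(Cc2nn(C)c(=O)c3ccccc23)nnc1SCCCCCCCC(=O)Nc1ccc(Cl)cc1Cl` gives 190 nM in an assay on NK92 cells for inhibition of interleukin-15 (Homo sapiens), read by AlphaScreen, with stated times of 30 min and 1 h; on this read-out higher numbers stand for weaker inhibition and lower numbers for stronger inhibition;
compound 2 `CCOC(CCn1c(Cc2nn(C)c(=O)c3ccccc23)nnc1SCC(=O)Nc1ccc(Cl)cc1Cl)OCC` gives > 30000 nM in this assay, which is a limit;
compound 3 `Cn1c(Cc2nn(CCCO[Si](C)(C)C(C)(C)C)c(=O)c3ccccc23)nnc1SCCCCCCCC(=O)Nc1ccc(Cl)cc1Cl` gives > 30000 nM in this assay, which is a limit.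

Compound 3 thus stands at the limit of this assay, as does compound 2; only compound 1 is reported as a number. For the measured compounds named here, the one step that joins compound 3 to a numbered compound is an at least 150-fold higher number from compound 1 to compound 3 (2.19 log units; beyond the scatter), and both limits sit at the limit of > 30000 nM in this assay, at which 2 of the 3 values shown sit.

Compound 4 `CN(C)CCCn1nc(Cc2nnc(SCCCCCCCC(=O)Nc3ccc(Cl)cc3Cl)n2C)c2ccccc2c1=O` differs from compound 3 by a group of 3 heavy atoms (2 carbon, 1 nitrogen; no ring) in place of a group of 8 heavy atoms (6 carbon, 1 oxygen, 1 silicon; no ring), on a saturated chain carbon, three bonds along the chain from an aromatic nitrogen. The step from compound 1 to compound 3 bears on it: a large group on that chain carbon went with a large loss, and compound 4 carries a smaller group there. Compound 4 is therefore expected to move back toward a measurable number, with the estimated step of an at least 20-fold lower number from compound 3 to compound 4 (1.30 log units; beyond the scatter). The estimate for compound 4 is 1500 nM, with a range from 150 nM to 15000 nM.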

Compound 4, half-maximal inhibitory concentration: > 30000 nM
Compound 4: no number, only a limit; the forecaster's own chance of this, stated with the estimate: 25%; middle value at least 20-fold (1.30 log units) from the limit.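

Replacing the silyl ether end of the chain with dimethylamino did not bring back a number in this assay: compound 4 gives > 30000 nM, which is a limit. The step between this limit and that of compound 3 cannot be read, so neither tail can be placed ahead of the other. What compound 4 adds is that a change to dimethylamino on this saturated chain carbon, three bonds along the chain from an aromatic nitrogen, still leaves an at least 150-fold higher number from compound 1 to compound 4 (2.19 log units; beyond the scatter), so the loss is not tied to the silyl ether alone: the limit of > 30000 nM in this assay, at which 3 of the 4 values shown sit.

For the compounds shown here, compound 1 remains the only compound with a number, which leaves open how much of a tail this place can carry before the limit is reached. A shorter chain, or a hydroxyl or a carboxylic acid in place of dimethylamino, could show whether any tail here keeps a measurable number.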